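From hydroxy to butyl: what size of step to expect

This account rests on a few compounds, and the source may have more. Where it says the series, first, only, none or still open, it means among the compounds named here.

Measured so far:
- compound 1 `CCCCSSC(=S)N(CC)CC` with 7400 nM
- compound 2 `CCN(CC)C(=S)SSCCO` with 10000 nM

In a functional assay on MDA-MB-231 cells (Homo sapiens) for antiproliferative activity, read by MTT assay, with a stated time of 72 h (on this read-out lower numbers stand for stronger inhibition and higher numbers for weaker inhibition), compound 2 gives 10000 nM and so stands level, within the scatter, with compound 1 at 7400 nM in this pair. Only these two numbers exist so far.

Within the data shown here, compound 3 `CCCCCCSSC(=S)N(CC)CC` has no measurement yet. Its difference from compound 2 is counted as butyl in place of hydroxy on a saturated chain carbon, two bonds along the chain from a sulfur in full: butyl in place of hydroxy on a saturated chain carbon, two bonds along the chain from a sulfur.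

Among the measured compounds shown here, one measured step bears on this change, namely a 1.4-fold higher number from compound 1 to compound 2 (0.13 log units; within the scatter) at that same place, where hydroxy stands in place of ethyl. Compound 3 carries butyl where compound 1 carries ethyl, so it also lacks the hydroxy. A single small step shows no trend, so no change beyond the scatter is expected, with at most a slight drift toward a lower number. The estimate means a 1.5-fold lower number from compound 2 to compound 3 (0.19 log units; within the scatter) as the expected step. For compound 3 the estimated value is 6500 nM with an expected range from 2500 nM to 14000 nM as a working guess.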

Compound 3, half-maximal inhibitory concentration: > 10000 nM
Compound 3: no number, only a limit (the forecaster's own chance of this, stated with the estimate: 5%); at least 1.5-fold (0.18 log units) between middle value and limit.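

In this assay compound 3 reaches a limit of the assay and not a number: the limit of > 10000 nM in this assay, at which 1 of the 3 values shown sits.

The step with butyl in place of hydroxy, a number no lower from compound 2 to compound 3 (the limit leaves the size open), cannot be read, so the comparison with the ethyl-bearing compound carries what can be said: an at least 1.3-fold higher number from compound 1 to compound 3 (0.13 log units; that floor lies within the scatter), with ethyl in place of hydrogen on a saturated chain carbon, four bonds along the chain from a sulfur. The earlier pair showed only that swapping ethyl for hydroxy at this position left the number within the scatter, whereas this result adds that extending the chain with butyl gives no sign of stronger inhibition in this series, though the floor of that step is too small to show that the longer chain weakens it.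

On these data alone, the true value of compound 3 stays unknown, so how much weaker it is than compound 1, if at all, remains open. Also open, as far as these compounds go, is how this position responds to groups of a different kind on the chain, such as an amine, a carboxylic acid or a phenyl ring.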